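The source may report more compounds than this note shows. Statements on the series, on what has been measured and on what is new or still open speak of the compounds shown alone.

In a functional assay on PC-3 cells (Homo sapiens) for inhibition, read by MTT assay, with a stated time of 24 h, tested at 1 ug/mL (a higher number here means more inhibition of growth at the concentration tested, a lower number less inhibition of growth), compound 1 `O=C(CCCCC1CCSS1)Nc1ccccc1Cl` carries the entry "not determined" (no result reported) and no number, while compound 2 `O=C(CCCCC1CCSS1)Nc1cccc(C(F)(F)F)c1` gives 8.44% as the only number shown, so it cannot yet be ranked against another compound. Compound 3 `O=C(CCCCC1CCSS1)Nc1ccc([N+](=O)[O-])c(C(F)(F)F)c1` differs from compound 2 by a single change, nitro in place of hydrogen on an aromatic carbon in which nitro takes the place of hydrogen on an aromatic carbon, ortho to a trifluoromethyl group and para to a large group. Among the compounds with values here, no measured step is available as a guide, so no shift beyond the usual scatter is expected in this assay for this change. The estimated step is a number 3.6 percentage points higher from compound 2 to compound 3 (within the scatter) and stays small. Compound 3 is expected at 12% with a range from 2% to 25% in this estimate.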

Compound 3, percent growth inhibition at one concentration: "not active" (no number reported)
Compound 3 has no reported number here; there is nothing to compare the estimate with.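

Within the data shown here, compound 3 carries the entry "not active" (no number reported) with no number, so no step from compound 2 to compound 3 can be read. The compounds shown leave open how the added nitro group shifts growth inhibition. No evidence bearing on this result is available.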